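Trifluoromethyl for methyl on the phenyl of compound 2

A few compounds are considered here, and "the series" means these few. Any claim that something is new, unique, unknown or untested is made for them only; others in the source may bear on it.

Measured compounds:
compound 1 `COc1cc2c(Oc3ccc(NC(=O)c4nn(-c5ccccc5)c(=O)cc4C)cc3F)ccnc2cc1OCCCN1CCCC1`: 460 nM
compound 2 `COc1cc2c(Oc3ccc(NC(=O)c4nn(-c5ccccc5C)c(=O)cc4C)cc3F)ccnc2cc1OCCCN1CCCC1`: 1590 nM
compound 3 `COc1cc2c(Oc3ccc(NC(=O)c4nn(-c5ccccc5C)c(=O)cc4C)cc3F)ccnc2cc1OCCCN1CCN(C)CC1`: 3420 nM

In a functional assay on NCI-H460 cells (Homo sapiens) for inhibition, read by MTT assay, with a stated time of 72 h (on this read-out lower numbers stand for stronger inhibition and higher numbers for weaker inhibition), compound 2 stands second highest of the three numbers; compound 3 sits a 2.2-fold higher number from compound 2 to compound 3 (0.33 log units; beyond the scatter) away, and compound 1 is a 3.5-fold higher number from compound 1 to compound 2 (0.54 log units; beyond the scatter) lower. Compound 4 `COc1cc2c(Oc3ccc(NC(=O)c4nn(-c5ccccc5C(F)(F)F)c(=O)cc4C)cc3F)ccnc2cc1OCCCN1CCCC1` is not yet measured. It differs from compound 2 by trifluoromethyl in place of methyl on an aromatic carbon. Going by the values given here, the only measured step that bears on this position is a 3.5-fold higher number from compound 1 to compound 2 (0.54 log units; beyond the scatter), where adding a group on that aromatic carbon weakened inhibition. Among the compounds with values here, no step shows a trifluoromethyl directly. Compound 4 is therefore expected to be a modest step in the same direction, giving a 1.9-fold higher number from compound 2 to compound 4 (0.28 log units; within the scatter) in this assay. The estimate for compound 4 is 3000 nM, within a range of 1200 nM to 8000 nM.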

Compound 4, half-maximal inhibitory concentration: 210 nM
The estimate for compound 4 lay 14-fold (1.15 log units) above the measured number; measured number outside the range, below it.
By their numbers in this assay, from the lowest: compound 4; then compound 1; then compound 2; then compound 3.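

In this assay, the effect of a group on this aromatic carbon depends on which group it is: the change to trifluoromethyl gives a 7.6-fold lower number from compound 2 to compound 4 (0.88 log units; beyond the scatter) and also a 2.2-fold lower number from compound 1 to compound 4 (0.34 log units; beyond the scatter) against the unsubstituted phenyl. The weakening seen with methyl therefore does not hold for every group here, and a substituent at this place can strengthen inhibition. No measurement at hand accounts for the difference between methyl and trifluoromethyl.

From the compounds shown here alone, whether a chlorine or a methoxy group on this carbon would follow methyl or trifluoromethyl remains open. So does whether trifluoromethyl has the same effect with the 4-methylpiperazin-1-yl of compound 3.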